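The compounds below may be only part of what the source reports. "The series", "measured", "known", "first", "only" and "open" are said of these compounds alone.

Compound 1 `C=C1C(=O)[C@]23C[C@@]1(O)CC[C@H]2c1ccc(O)c(C)c1[C@@H]3Cn1cc(-c2ccc(Br)cc2)nn1` and compound 2 `C=C1C(=O)[C@]23C[C@@]1(O)CC[C@H]2c1ccc(O)c(C)c1[C@@H]3Cn1cc(-c2ccccn2)nn1` share one core and differ only in the group sitting on an aromatic carbon of a five-membered aromatic ring with 3 nitrogen. In a functional assay on SMMC-7721 cells (Homo sapiens) for cytotoxicity, read by MTT assay, with a stated time of 4 days (on this read-out higher numbers stand for weaker inhibition and lower numbers for stronger inhibition), compound 1 gives 1300 nM, and compound 2 gives 1270 nM. The step of a 1.0-fold lower number from compound 1 to compound 2 (0.01 log units; within the scatter) shows that swapping 4-bromophenyl for pyridin-2-yl left the read-out essentially where it was. Among the measured compounds shown here, compound 2 thus holds the smaller of the two numbers measured so far, but its gap to compound 1 lies within the scatter, so the two cannot be told apart.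

Compound 3 `C=C1C(=O)[C@]23C[C@@]1(O)CC[C@H]2c1ccc(O)c(C)c1[C@@H]3Cn1cc(-c2ccc(F)cc2)nn1` carries the next change: 4-fluorophenyl in place of pyridin-2-yl on an aromatic carbon. For the measured compounds named here, only one measured step bears on this exchange, the one from compound 1 to compound 2, and it was flat: a bromine-bearing ring and a nitrogen-containing ring gave the same result at this position. With that single precedent, the expected step of a 1.0-fold higher number from compound 2 to compound 3 (0.01 log units; within the scatter) is one that stays within the scatter. Compound 3 is therefore expected to give about 1300 nM, most likely between 500 nM and 3500 nM.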

Compound 3, half-maximal inhibitory concentration: 850 nM
Estimate against measurement, compound 3: 1.5-fold (0.18 log units) above, and the stated range covers the measured number.
By their numbers in this assay, from the lowest: compounds 3, 2 and 1 (each within the scatter of the next).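

Replacing pyridin-2-yl with 4-fluorophenyl on this aromatic carbon of the five-membered ring gives a 1.5-fold lower number from compound 2 to compound 3 (0.17 log units; within the scatter) in this assay, so a ring of carbon only and a ring holding one nitrogen cannot be told apart on this read-out. The pair of compound 1 and compound 3 adds a comparison that the earlier step, which exchanged a whole ring, could not give: with the phenyl ring kept, fluoro in place of bromo gives a 1.5-fold lower number from compound 1 to compound 3 (0.18 log units; within the scatter), so these two halogens cannot be told apart either. All three aromatic groups therefore sit within the scatter of one another at this position, and nothing at hand gives a reason for this flat picture.

Every compound shown keeps a six-membered aromatic ring on this carbon, which leaves open whether a morpholine, a carboxylic acid or a plain alkyl chain in its place would stay in the same range. Going by these compounds, it also remains open whether a phenyl ring bearing a methoxy or an amine, rather than a halogen, would bring a step beyond the scatter.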